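Second trifluoromethyl on the urea aryl of compound 1

The source may hold more compounds than are shown below. What is called first, only, known or untested is meant among the compounds shown, and "the series" means these compounds.

Measured compounds:
compound 1 `O=C(Nc1cccc(-n2cc(-c3ccncc3)c(-c3ccc(Cl)c(O)c3)n2)c1)Nc1cccc(C(F)(F)F)c1` — 1290 nM
compound 2 `O=C(Nc1cccc(-n2cc(-c3ccncc3)c(-c3ccc(Cl)c(O)c3)n2)c1)Nc1ccc(Cl)c(Cl)c1` — 1040 nM
compound 3 `COc1cc(-c2nn(-c3cccc(NC(=O)Nc4cccc(C(F)(F)F)c4)c3)cc2-c2ccncc2)ccc1Cl` — 656 nM

Of the compounds shown here, three sharing one core have been tested in a functional assay on ACHN cells (Homo sapiens) for inhibition, read by sulforhodamine B assay, with a stated time of 48 h; a lower number here means a stronger inhibitor of growth, a higher number a weaker inhibitor of growth. Compound 1 gives the highest of the three numbers there, yet its distance to the others is small: a 1.2-fold lower number from compound 1 to compound 2 (0.09 log units; within the scatter) and a 2.0-fold lower number from compound 1 to compound 3 (0.29 log units; within the scatter), both within the scatter, so the three values cannot be ordered.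

Compound 4 `O=C(Nc1cccc(-n2cc(-c3ccncc3)c(-c3ccc(Cl)c(O)c3)n2)c1)Nc1cc(C(F)(F)F)cc(C(F)(F)F)c1` has not been measured. It differs from compound 1 in one place: trifluoromethyl in place of hydrogen on an aromatic carbon. For the measured compounds named here, the step that bears most on this change is the one from compound 1 to compound 2, where the aryl group on the amide-type nitrogen was exchanged, with a 1.2-fold lower number from compound 1 to compound 2 (0.09 log units; within the scatter), a change that stayed within the scatter. The other step, from compound 1 to compound 3, touches a different part of the molecule and also stayed within the scatter. Going by the values given here, nothing measured so far points to a step beyond the scatter for an added trifluoromethyl on that ring, so no shift beyond the scatter is expected in this assay.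

Compound 4 is therefore estimated at 1100 nM, in the range 400 nM to 3500 nM, meaning an expected step of a 1.2-fold lower number from compound 1 to compound 4 (0.07 log units; within the scatter).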

Compound 4, concentration for 50% growth inhibition: 624 nM
Compound 4: middle estimate off by 1.8-fold (0.25 log units), on the high side; the measured number falls inside the stated range.
By their numbers in this assay, from the lowest: compounds 4, 3, 2 and 1 (each within the scatter of the next, the first and the last beyond it).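

In this assay, adding a trifluoromethyl meta to the existing trifluoromethyl group gives a 2.1-fold lower number from compound 1 to compound 4 (0.32 log units; beyond the scatter), a modest step but the first in this set to lie beyond the scatter. The earlier change on this same ring, a 1.2-fold lower number from compound 1 to compound 2 (0.09 log units; within the scatter), stayed within the scatter, so only compound 4 shows that a change on this ring can move the number measurably, and here it moved it lower. No evidence is available to explain this step.

As far as these compounds go, whether the step is specific to trifluoromethyl remains open, since a smaller or different group at this place, such as a methoxy, an amine or a carboxylic acid, could behave otherwise. From the compounds shown here alone, it is also open whether the second trifluoromethyl would give a similar step when combined with the methyl on the oxygen of compound 3.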